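Aryl urea series on the quinoline core: chloro analogue

The source may report more compounds than this note shows. Statements on the series, on what has been measured and on what is new or still open speak of the compounds shown alone.

Compound 2, `COc1cc(NC(C)CCCNC(=O)NNC(=O)Nc2ccc(Br)cc2)c2ncccc2c1`, is the higher of the two numbers at hand in a functional assay on NCI-H460 cells (Homo sapiens) for inhibition, read by MTT assay, with a stated time of 72 h (on this read-out lower numbers stand for stronger inhibition and higher numbers for weaker inhibition), where compound 2 gives 27000 nM; compound 1, `COc1cc(NC(C)CCCNC(=O)Nc2cccc(F)c2)c2ncccc2c1`, gives 24000 nM, and the two lie within the scatter of each other. Compound 3, `COc1cc(NC(C)CCCNC(=O)Nc2ccc(Cl)cc2)c2ncccc2c1`, differs from compound 2 by 4-chlorophenyl in place of ((4-bromophenyl)carbamoyl)amino on an amide-type nitrogen. For the measured compounds named here, the only step that bears on this place is a 1.1-fold higher number from compound 1 to compound 2 (0.05 log units; within the scatter), which went the other way and stayed within the scatter. No shift beyond the scatter is therefore expected for a 1.2-fold lower number from compound 2 to compound 3 (0.09 log units; within the scatter). Compound 3 is estimated at 22000 nM, within 8000 nM to 60000 nM.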

Compound 3, half-maximal inhibitory concentration: 34000 nM
Beside the measured number, compound 3's estimate is 1.5-fold (0.19 log units) below it; low and high end bracket the measured number.
By their numbers in this assay, from the lowest: compounds 1, 2 and 3 (each within the scatter of the next).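

In this assay, 4-chlorophenyl in place of ((4-bromophenyl)carbamoyl)amino on the amide-type nitrogen gives a 1.3-fold higher number from compound 2 to compound 3 (0.10 log units; within the scatter), and 4-chlorophenyl in place of 3-fluorophenyl gives a 1.4-fold higher number from compound 1 to compound 3 (0.15 log units; within the scatter). All three groups at this position now lie within the scatter of one another, so neither exchange separates them on this read-out. Nothing at hand bears on why the three numbers stay so close. The compounds shown leave open whether an amine or a carboxylic acid on the aryl ring, or a longer alkyl chain in its place, would move the number beyond the scatter.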